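A few compounds are considered here, and "the series" means these few. Any claim that something is new, unique, unknown or untested is made for them only; others in the source may bear on it.

The measured compounds and their numbers in a functional assay on M21 cells (Homo sapiens) for antiproliferative activity, read by sulforhodamine B assay, with a stated time of 48 h; a lower number here means a stronger inhibitor, a higher number a weaker inhibitor:

compound 1 `CCCCCc1ccc(NS(=O)(=O)c2ccc(N3CCNC3=O)cc2)cc1` gives 870 nM
compound 2 `COc1ccc(NS(=O)(=O)c2ccc(N3CCNC3=O)cc2)cc1` gives 580 nM
compound 3 `O=C1NCCN1c1ccc(S(=O)(=O)Nc2ccc(OC(F)F)cc2)cc1` gives 410 nM

Among these three, compound 3 has the lowest number. Compound 2 is nearest to it, and that gap is within the scatter, so the two cannot be ranked against each other. Compound 1 is furthest, and the step of a 2.1-fold lower number from compound 1 to compound 3 (0.33 log units; beyond the scatter) is beyond the scatter.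

Compound 4 `CC(C)Cc1ccc(NS(=O)(=O)c2ccc(N3CCNC3=O)cc2)cc1` has not yet been measured. It differs from compound 3 in one place: isobutyl in place of difluoromethoxy on an aromatic carbon. The group entering is a four-carbon chain without oxygen or fluorine, which in kind is closer to the pentyl of compound 1 than to the groups of compound 2 or compound 3.

For the measured compounds named here, two measured steps bear on this. The step of a 2.1-fold lower number from compound 1 to compound 3 (0.33 log units; beyond the scatter) runs in the opposite direction, pentyl out and difluoromethoxy in, and is modest. The step of a 1.4-fold lower number from compound 2 to compound 3 (0.15 log units; within the scatter) shows that exchanging methyl for difluoromethyl on the oxygen stayed within the scatter. Reading the pentyl-to-difluoromethoxy step backwards, a modest rise toward the number of compound 1 is expected for compound 4. The expected step is a 1.7-fold higher number from compound 3 to compound 4 (0.23 log units; within the scatter). Compound 4 is therefore estimated at 700 nM, with a range from 350 nM to 1400 nM.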

Compound 4, half-maximal inhibitory concentration: > 1000 nM
Compound 4: only a limit was reported; the forecaster's own chance of this, stated with the estimate: 3%; middle value at least 1.4-fold (0.15 log units) away from the limit.
By their numbers in this assay, from the lowest: compounds 3, 2 and 1 (each within the scatter of the next, the first and the last beyond it). At a limit, above all of these: compound 4.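

In this assay compound 4 gives > 1000 nM as a limit of the assay and not a number: the limit of > 1000 nM in this assay, at which 1 of the 4 values shown sits. Even so, the limit allows one clear reading: an at least 2.4-fold higher number from compound 3 to compound 4 (0.38 log units; beyond the scatter) is a real loss on this aromatic carbon, and it comes from exchanging two groups with the same count of heavy atoms, so at this place that count alone does not fix the number. The other two steps, an at least 1.7-fold higher number from compound 2 to compound 4 (0.23 log units; that floor lies within the scatter) and an at least 1.1-fold higher number from compound 1 to compound 4 (0.06 log units; that floor lies within the scatter), do not set compound 4 apart from compound 2 or from compound 1, which leaves the branched isobutyl and the straight pentyl unseparated.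

On these data alone, the true number of compound 4 stays open, and with it whether branching in an all-carbon chain matters here at all. Also open, as far as these compounds go, is what an amine, a hydroxyl or a carboxylic acid would give on this aromatic carbon, and what a chain longer than pentyl would do.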